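A few compounds are considered here, and "the series" means these few. Any claim that something is new, unique, unknown or untested is made for them only; others in the source may bear on it.

Measured so far in a functional assay on JAR cells (Homo sapiens) for inhibition, read by MTT assay, with a stated time of 72 h, tested at 10 uM; on this read-out lower numbers stand for less inhibition and higher numbers for more inhibition at the one concentration tested (going by the name of the read-out):
- compound 1, `CCOC(=O)C1=C(Nc2ccccc2)S/C(=C\c2ccccc2)C1=O`: 20.3%
- compound 2, `CCOC(=O)C1=C(Nc2ccccc2)S/C(=C\c2cccc(C(=O)O)c2)C1=O`: 50.6%
- compound 3, `CCOC(=O)C1=C(Nc2ccccc2)S/C(=C\c2cc3ccncc3[nH]2)C1=O`: 26.3%

Compound 3 stands second highest of the three numbers in this assay. Its nearest neighbour is compound 1, a number 6 percentage points higher from compound 1 to compound 3 (within the scatter), a gap within the scatter; its furthest is compound 2, a number 24.3 percentage points lower from compound 2 to compound 3 (beyond the scatter), a gap beyond the scatter. Compound 2 itself stands apart from compound 1, a number 30.3 percentage points higher from compound 1 to compound 2 (beyond the scatter).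

Compound 4, `CCOC(=O)C1=C(Nc2ccccc2)S/C(=C\c2cc3ncccc3[nH]2)C1=O`, is not yet measured. Relative to compound 3 the change is a group of 9 heavy atoms (7 carbon, 2 nitrogen; one five-membered aromatic ring with 1 hetero atom, one six-membered aromatic ring with 1 hetero atom) in place of a group of 9 heavy atoms (7 carbon, 2 nitrogen; one five-membered aromatic ring with 1 hetero atom, one six-membered aromatic ring with 1 hetero atom), on a double-bonded chain carbon bound to a double-bonded ring carbon.

For the measured compounds named here, the steps that bear on this position are those from compound 1 and compound 2 into compound 3: the first lies within the scatter, the second is modest. Both replace the whole group on that chain carbon; here only the joining of the same atoms changes, a smaller alteration than either. No step beyond the scatter is therefore expected in this assay, and the number for compound 4 is estimated at 26%, within 12% to 42%, an expected step of a number 0.3 percentage points lower from compound 3 to compound 4 (within the scatter).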

Compound 4, a percentage reported as inhibition, at one concentration (the size of the read-out at that concentration, not a potency): 74.8%
For compound 4 the middle estimate is 48.8 percentage points below the measured one, outside the stated range (above it).
By their numbers in this assay, from the lowest: compounds 1 and 3 (each within the scatter of the next); then compound 2; then compound 4.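

In this assay, the place on a double-bonded chain carbon bound to a double-bonded ring carbon responds to how the atoms of the group are joined, not only to which atoms it holds: with the same atoms and the same hydrogen-bond donor and acceptor counts, a number 48.5 percentage points higher from compound 3 to compound 4 (beyond the scatter) is large and beyond the scatter. Compound 3 had shown no step beyond the scatter from compound 1, so the earlier data gave no sign of this sensitivity. The entering group also reads above the carboxy-bearing group, with a number 24.2 percentage points higher from compound 2 to compound 4 (beyond the scatter) as a modest step, and above the all-carbon aromatic ring, with a number 54.5 percentage points higher from compound 1 to compound 4 (beyond the scatter) as a large one.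

For the compounds shown here, whether an amine or a methoxy group on the group in compound 4 would preserve this reading stays open, and one concentration gives no potency for any compound. Nothing measured here accounts for the difference between compound 3 and compound 4.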